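From 4-chlorophenyl to thiophen-2-yl on a shared core

A few compounds are considered here, and "the series" means these few. Any claim that something is new, unique, unknown or untested is made for them only; others in the source may bear on it.

In a functional assay (aorta) with Oryctolagus cuniculus as the target (on this read-out lower numbers stand for stronger inhibition and higher numbers for weaker inhibition), compound 3 `CC1=C(C)C(=O)C(C(CCCCCC(=O)O)c2ccc(Cl)cc2)=C(C)C1=O` gives 280 nM. That is within the usual scatter of compound 1 `CC1=C(C(CCCCCC(=O)O)c2ccccc2)C(=O)c2ccccc2C1=O`, which has a different core and gives 240 nM. The core of compound 3 is shared by compound 2 `CC1=C(C)C(=O)C(C(CCCCCC(=O)O)c2cccc(F)c2)=C(C)C1=O`, which lies well apart and gives 1900 nM.

Compound 4 `CC1=C(C)C(=O)C(C(CCCCCC(=O)O)c2cccs2)=C(C)C1=O` keeps everything in compound 3 except one group: thiophen-2-yl in place of 4-chlorophenyl on a saturated chain carbon bound to a double-bonded ring carbon and a saturated chain carbon. Among the measured compounds shown here, only one measured step touches this place, a 6.8-fold lower number from compound 2 to compound 3 (0.83 log units; beyond the scatter). It shows that exchanging the aromatic ring here can move the number in this assay beyond the scatter. Yet that step only swaps one substituted phenyl for another, and no thiophen-2-yl compound has been measured, so the direction remains uncertain.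

Of the two compounds with this core, compound 3 holds the lower number, so a small rise is more likely than a fall. The expected change is a 1.8-fold higher number from compound 3 to compound 4 (0.25 log units; within the scatter), not clearly beyond the scatter. For compound 4 the estimate is 500 nM, with an expected range from 150 nM to 1700 nM.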

Compound 4, half-maximal inhibitory concentration: 760 nM
Compound 4: the middle estimate sits 1.5-fold (0.18 log units) below what was measured; the range from low to high includes it.
By their numbers in this assay, from the lowest: compounds 1 and 3 (each within the scatter of the next); then compound 4; then compound 2.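

Changing the ring itself, from a six-membered carbon ring to a five-membered ring holding sulfur, also moves the number in this assay beyond the scatter, with a 2.7-fold higher number from compound 3 to compound 4 (0.43 log units; beyond the scatter) and a 2.5-fold lower number from compound 2 to compound 4 (0.40 log units; beyond the scatter) as the two readings. This place therefore responds to more than swaps between substituted phenyl rings, and on the shared core thiophen-2-yl falls in the middle, with 4-chlorophenyl giving the lowest number of the three and 3-fluorophenyl the highest. Nothing available explains why these three rings rank in this order.

Going by these compounds, compounds 2 and 3 differ in both the halogen and where it sits, so it stays open which of the two matters; a 4-fluorophenyl group would separate them. On these data alone, how another five-membered ring, such as furan-2-yl, would compare with thiophen-2-yl also remains open.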